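The compounds below may be only part of what the source reports. "The series", "measured", "known", "first", "only" and "open" are said of these compounds alone.

Measured so far in a functional assay on BGC-823 cells (Homo sapiens) for antiproliferative activity, read by MTT assay, tested at 1 uM; a lower number here means a weaker effect, a higher number a stronger effect of the compound at the concentration tested:
- compound 1 `COc1cc(C(=O)N/N=C/c2cccc(F)c2)cc(OC)c1OC` gives 13.6%
- compound 2 `COc1cc(C(=O)N/N=C/c2ccc(F)cc2)cc(OC)c1OC` gives 50.9%
- compound 3 `COc1cc(C(=O)N/N=C/c2ccc(Cl)c([N+](=O)[O-])c2)cc(OC)c1OC` gives -5.8%

Compound 3 stands lowest of the three numbers in this assay. Its nearest neighbour is compound 1, whose value sits higher by a gap beyond the usual scatter; compound 2 sits furthest from it, again beyond the scatter. All three share the same core and differ only in the substitution of the ring on the carbon with a double bond to nitrogen.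

Compound 4 `COc1cc(C(=O)N/N=C/c2ccc(Cl)c(Cl)c2)cc(OC)c1OC` has not yet been measured in this assay. It differs from compound 3 in one place: chloro in place of nitro on an aromatic carbon. Among the measured compounds shown here, the only step measured so far is a number 37.3 percentage points higher from compound 1 to compound 2 (beyond the scatter), which shows that a change of substitution on this ring can move the read-out by a large amount; it does not, however, exchange a nitro for a chloro, so it bears on the present step only in showing the range of movement such a ring change can produce. For the measured compounds named here, no measured pair tells the direction of a nitro-to-chloro exchange.

The expectation is therefore a modest rise, a number 15.8 percentage points higher from compound 3 to compound 4 (beyond the scatter), with wide uncertainty. The estimate for compound 4 in this assay is 10%, expected to fall between -10% and 35%.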

Compound 4, a percentage reported as inhibition, at one concentration (the size of the read-out at that concentration, not a potency): 29.6%
For compound 4 the middle estimate is 19.6 percentage points below the measured one; the range from low to high includes it.
By their numbers in this assay, from the lowest: compound 3; then compound 1; then compound 4; then compound 2.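

Chloro in place of nitro, at the aromatic carbon ortho to a chloro group and meta to a large group, gives in this assay a step of a number 35.4 percentage points higher from compound 3 to compound 4 (beyond the scatter) and so shows that this position alone can carry a large change, with the other chloro held constant. The 3,4-dichlorophenyl ring falls between the two monofluorophenyl rings, with a number 21.3 percentage points lower from compound 2 to compound 4 (beyond the scatter) and a number 16 percentage points higher from compound 1 to compound 4 (beyond the scatter) as its steps, so among compounds 1, 2 and 4 neither the second halogen nor the 3,4-dichlorophenyl pattern puts compound 4 at either end of the order. No supporting data accompany these results to explain any of the three steps.

As far as these compounds go, whether the rise belongs to chloro in particular or would also appear with another group at this carbon, such as an amine, a carboxylic acid or a longer chain, remains open. The contribution of the chloro shared by compound 3 and compound 4 also remains unresolved, as does whether these steps would hold beyond this single assay at this single concentration.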